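One Added Methyl at the Edge of the Assay

The source may hold more compounds than are shown below. What is called first, only, known or untested is meant among the compounds shown, and "the series" means these compounds.

In a functional assay on HeLa cells (Homo sapiens) for antiproliferative activity, read by MTT assay, with a stated time of 72 h (a higher number here means a weaker inhibitor, a lower number a stronger inhibitor), compound 3 `C/C=C/C(=O)Nc1cccc(Oc2nc(Nc3ccc(OC)cc3)nc3c2CSCC3)c1` gives > 50000 nM, which is a limit of the assay and not a number. Its close relative, compound 2 `C=CC(=O)Nc1cccc(Oc2nc(Nc3ccc(OC)cc3)nc3c2CSCC3)c1`, gives a real number of 20900 nM. Among the measured compounds shown here, with prop-1-en-1-yl in place of vinyl on a carbonyl carbon, the one measured step of this kind is an at least 2.3-fold higher number from compound 2 to compound 3 (0.37 log units; beyond the scatter). Compound 4 `CC/C=C/C(=O)Nc1cccc(Oc2nc(Nc3ccc(OC)cc3)nc3c2CSCC3)c1` carries one further change: methyl in place of hydrogen on a saturated chain carbon bound to a double-bonded chain carbon. This turns prop-1-en-1-yl into but-1-en-1-yl.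

The resulting (but-1-en-1-yl)carbonyl group already occurs in compound 1 `CC/C=C/C(=O)Nc1cccc(Oc2nc(Nc3ccn(C)n3)nc3c2CSCC3)c1`, which differs elsewhere in its structure. In this assay, compound 1 gives > 50000 nM, again a limit. The measurements therefore crowd against one boundary: the limit of > 50000 nM in this assay, at which 2 of the 3 values shown sit. On these data alone, the true position of compound 3 beyond its limit is unknown, so the size of the next step cannot be read directly. For the measured compounds named here, no measured step points toward a stronger inhibitor, so the expected result is little or no real change, with a step that the limit leaves unreadable from compound 3 to compound 4 as the estimate. For compound 4 the estimated value is 60000 nM, with an expected range from 30000 nM to 120000 nM.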

Compound 4, half-maximal inhibitory concentration: 27200 nM
The estimate for compound 4 lay 2.2-fold (0.34 log units) above the measured number; measured number outside the range, below it.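

In this assay, compound 4 is the first compound shown with the (but-1-en-1-yl)carbonyl group to give a real number, and both steps reaching it are only floors: an at least 1.8-fold lower number from compound 3 to compound 4 (0.26 log units; that floor lies within the scatter) for the added methyl, and an at least 1.8-fold lower number from compound 1 to compound 4 (0.26 log units; that floor lies within the scatter) for 4-methoxyphenyl in place of 1-methyl-1H-pyrazol-3-yl on a nitrogen on an aromatic ring. The vinyl and but-1-en-1-yl amides cannot be told apart, with a 1.3-fold higher number from compound 2 to compound 4 (0.11 log units; within the scatter), so a longer chain on the carbonyl carbon does not give a steady loss across these compounds, and compound 4 goes against the trend suggested by an at least 2.3-fold higher number from compound 2 to compound 3 (0.37 log units; beyond the scatter). The true size of the methyl step stays unknown because compound 1 and compound 3 each rest on a limit and not on a number: the limit of > 50000 nM in this assay, at which 2 of the 4 values shown sit.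

On these data alone, how far compound 3 lies beyond its limit remains open, and so does whether the result for compound 4 reflects a real recovery or only scatter. Also open, as far as these compounds go, is whether a longer chain such as hex-1-en-1-yl, or a dimethylamine at the end of the chain, would keep a readable number in this assay.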